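Sulfonyl substituent change from compound 2 to compound 4

A few compounds are considered here, and "the series" means these few. Any claim that something is new, unique, unknown or untested is made for them only; others in the source may bear on it.

Measured compounds:
compound 1 `O=C(NCc1ccc(S(=O)(=O)N2CCOCC2)cc1)c1cc2ccncc2o1`: 32 nM
compound 2 `O=C(NCc1ccc(S(=O)(=O)C2CCOCC2)cc1)c1cc2ccncc2o1`: 47 nM
compound 3 `O=C(NCc1ccc(S(=O)(=O)C2CCOCC2)cc1)c1cc2cnccc2[nH]1`: 88 nM

In an assay for inhibition of Nicotinamide phosphoribosyltransferase (Homo sapiens), with stated times of 15 min and 30 min (on this read-out lower numbers stand for stronger inhibition and higher numbers for weaker inhibition), compound 2 gives the second highest of the three numbers; the steps of a 1.5-fold higher number from compound 1 to compound 2 (0.17 log units; within the scatter) and a 1.9-fold higher number from compound 2 to compound 3 (0.27 log units; within the scatter) both lie within the scatter. Compound 4 `CC(C)N1CCC(S(=O)(=O)c2ccc(CNC(=O)c3cc4ccncc4o3)cc2)CC1` differs from compound 2 by 1-isopropylpiperidin-4-yl in place of oxan-4-yl on a sulfonyl sulfur. Among the measured compounds shown here, the only measured step at the sulfonyl sulfur, a 1.5-fold higher number from compound 1 to compound 2 (0.17 log units; within the scatter), stayed within the scatter, and no measured compound carries the entering group, so nothing in this assay points to a step beyond the scatter in either direction. For compound 4 the expected step is a 1.0-fold lower number from compound 2 to compound 4 (0.02 log units; within the scatter) in this assay. Compound 4 is therefore estimated at 45 nM, with a range from 15 nM to 140 nM.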

Compound 4, half-maximal inhibitory concentration: 71 nM
Compound 4: middle estimate off by 1.6-fold (0.20 log units), on the low side; the range from low to high includes it.
By their numbers in this assay, from the lowest: compounds 1, 2, 4 and 3 (each within the scatter of the next, the first and the last beyond it).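

In this assay the 1-isopropylpiperidin-4-yl group on a sulfonyl sulfur stays level with oxan-4-yl (a 1.5-fold higher number from compound 2 to compound 4 (0.18 log units; within the scatter)), although it brings 9 heavy atoms in place of 6. Against morpholin-4-yl the same group gives the first step at this place that lies beyond the scatter (a 2.2-fold higher number from compound 1 to compound 4 (0.35 log units; beyond the scatter)), and that step is modest. From the compounds shown here alone, a carboxylic acid or a longer chain on the sulfonyl sulfur remains open, as does the same exchange on the core of compound 3. No measurement at hand accounts for either step.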